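Methyl on a saturated ring carbon, carried across two cores

A few compounds are considered here, and "the series" means these few. Any claim that something is new, unique, unknown or untested is made for them only; others in the source may bear on it.

Measured so far in a functional assay on A549 cells (Homo sapiens) for inhibition, read by MTT assay, with a stated time of 72 h; a lower number here means a stronger inhibitor, a higher number a weaker inhibitor:
compound 1, `COc1cc2c(Oc3ccc(NC(=O)c4nn(-c5ccccc5OC(F)(F)F)c(=O)cc4C)cc3F)ccnc2cc1OCCCN1CCCCC1`, gives 120 nM
compound 2, `COc1cc2c(Oc3ccc(NC(=O)c4nn(-c5ccccc5OC(F)(F)F)c(=O)cc4C)cc3F)ccnc2cc1OCCCN1CCC(C)CC1`, gives 90 nM
compound 3, `COc1ccc(-n2nc(C(=O)Nc3ccc(Oc4ccnc5cc(OCCCN6CCCCC6)c(OC)cc45)c(F)c3)c(C)cc2=O)cc1`, gives 1500 nM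

Compound 1 and compound 2 share a core and differ only by methyl in place of hydrogen on a saturated ring carbon; that change gave a 1.3-fold lower number from compound 1 to compound 2 (0.12 log units; within the scatter). Compound 3 carries a different core, differing from compound 1 by 4-methoxyphenyl in place of 2-(trifluoromethoxy)phenyl on an aromatic nitrogen, and that change gave a 13-fold higher number from compound 1 to compound 3 (1.10 log units; beyond the scatter), so compound 3 stands well apart from the other two.

Compound 4, `COc1ccc(-n2nc(C(=O)Nc3ccc(Oc4ccnc5cc(OCCCN6CCC(C)CC6)c(OC)cc45)c(F)c3)c(C)cc2=O)cc1`, is not yet measured. It differs from compound 3 by methyl in place of hydrogen on a saturated ring carbon, the same change as that from compound 1 to compound 2, since the two place descriptions agree word for word. On the core of compound 1 this change stayed within the scatter, so for compound 4 the step of a 1.3-fold lower number from compound 3 to compound 4 (0.10 log units; within the scatter) is expected to be of the same small size, resting on the step from compound 1 to compound 2 and on the value of compound 3. Compound 4 is estimated at 1200 nM, between 550 nM and 2600 nM, pending the measurement.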

Compound 4, half-maximal inhibitory concentration: 1100 nM
The estimate for compound 4 lay 1.1-fold (0.04 log units) above the measured number; the range from low to high includes it.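

In this assay, methyl in place of hydrogen on the saturated ring carbon gave a 1.4-fold lower number from compound 3 to compound 4 (0.13 log units; within the scatter), and this small step matches the one seen on the core of compound 1: the same change on two cores in this assay, a 1.3-fold lower number (0.12 log units; within the scatter) from compound 1 to compound 2 and a 1.4-fold lower number (0.13 log units; within the scatter) from compound 3 to compound 4, 1.0-fold (0.01 log units) apart, within the scatter of two such steps.

With the 4-methylpiperidin-1-yl group in place, 4-methoxyphenyl in place of 2-(trifluoromethoxy)phenyl on the aromatic nitrogen gave a 12-fold higher number from compound 2 to compound 4 (1.09 log units; beyond the scatter), and this large step matches the one seen with piperidin-1-yl: the same change on two cores in this assay, a 13-fold higher number (1.10 log units; beyond the scatter) from compound 1 to compound 3 and a 12-fold higher number (1.09 log units; beyond the scatter) from compound 2 to compound 4, 1.0-fold (0.01 log units) apart, within the scatter of two such steps.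

Across these four compounds the two changes therefore carry over from one core to the other without either altering the size of the other's step, but this rests on only two cores in a single cell assay, and since both methyl steps lie within the scatter, they do not show that methyl itself changes the number at all.

As far as these compounds go, it remains open whether a group other than methyl at that ring carbon, such as a hydroxyl, a primary amine or a carboxylic acid, would also leave the number unchanged. From the compounds shown here alone, it also remains open whether a longer chain there would carry over between the two cores as methyl does.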